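The source may hold more compounds than are shown below. What is called first, only, known or untested is meant among the compounds shown, and "the series" means these compounds.

Compound 1 `O=c1nc2oc(CCCCl)cc2cn1Cc1cn(-c2ccccc2F)nn1` — > 100000 nM
Compound 2 `O=c1nc2oc(CCCCl)cc2cn1Cc1cn(-c2ccc(F)cc2)nn1` — > 100000 nM
Compound 3 `O=c1nc2oc(CCCCl)cc2cn1Cc1cn(Cc2ccccc2)nn1` — 75500 nM

In a functional assay on SW-620 cells (Homo sapiens) for antiproliferative activity, read by MTT assay, with a stated time of 72 h (a higher number here means a weaker inhibitor, a lower number a stronger inhibitor), compound 2 gives only a limit, > 100000 nM, and not a number. Compound 1 likewise reports only a limit, > 100000 nM. Both sit at the limit of > 100000 nM in this assay, at which 2 of the 3 values shown sit. For the measured compounds named here, compound 3 is the one compound with a number, 75500 nM. The readable steps, an at least 1.3-fold lower number from compound 1 to compound 3 (0.12 log units; that floor lies within the scatter) and an at least 1.3-fold lower number from compound 2 to compound 3 (0.12 log units; that floor lies within the scatter), both concern the group on the aromatic nitrogen, and a step that the two limits leave unreadable from compound 1 to compound 2 gives no size at all.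

Compound 4 `O=c1nc2oc(CCCCl)c(C#CCCCCCl)c2cn1Cc1cn(-c2ccc(F)cc2)nn1` differs from compound 2 by 6-chlorohex-1-yn-1-yl in place of hydrogen on an aromatic carbon. Going by the values given here, no measured step changes anything on the fused ring system; all three steps leave that part of the shared core untouched, so there is no measured guide to the direction or size of this change. The step is therefore estimated as a number no higher from compound 2 to compound 4 (the limit leaves the size open), meaning no movement beyond the scatter. Compound 4 is accordingly expected to give about 100000 nM in this assay, within a range from 30000 nM to 300000 nM, and a limit rather than a number is the more likely outcome.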

Compound 4, half-maximal inhibitory concentration: 69600 nM
For compound 4 the middle estimate is 1.4-fold (0.16 log units) above the measured one; the measured number falls inside the stated range.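

Compound 4 is the only compound shown that carries anything other than hydrogen on this aromatic carbon of the five-membered ring, so it gives the first reading of a change at this place in the shared core. In this assay, 6-chlorohex-1-yn-1-yl in place of hydrogen gives an at least 1.4-fold lower number from compound 2 to compound 4 (0.15 log units; that floor lies within the scatter), so the chain does not push the reading to the limit and compound 4 returns a number. The size of the step stays open, and only a floor can be stated, because compound 2 gives a limit and not a number: the limit of > 100000 nM in this assay, at which 2 of the 4 values shown sit.

The compounds shown leave open whether a saturated hexyl chain, a shorter alkynyl chain or a chain ending in an amine instead of chlorine would read differently at this carbon in this assay. They also leave open how the same chain would behave alongside the benzyl group of compound 3.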